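Thiosemicarbazones on the shared core: fluoro versus trifluoromethyl

The source may report more compounds than this note shows. Statements on the series, on what has been measured and on what is new or still open speak of the compounds shown alone.

Three thiosemicarbazones on the shared core are measured in a functional assay on HL-60 cells (Homo sapiens) for antiproliferative activity, read by sulforhodamine B assay, with a stated time of 72 h; a higher number here means a weaker inhibitor, a lower number a stronger inhibitor. Compound 1 `FC(F)(F)c1ccccc1NC(=S)N/N=C/c1ccc2ccccc2n1` gives 13200 nM. Compound 3 `Fc1ccc(NC(=S)N/N=C/c2ccc3ccccc3n2)cc1` gives 17000 nM, a value within the scatter of that of compound 1. For compound 2 `Fc1ccccc1NC(=S)N/N=C/c1ccc2ccccc2n1` only a limit of the assay is reported, > 100000 nM, as given under (the limit of > 100000 nM in this assay, at which 1 of the 3 values shown sits).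

Two measured steps start from compound 2. The first is trifluoromethyl in place of fluoro on an aromatic carbon and gives an at least 7.5-fold lower number from compound 2 to compound 1 (0.87 log units; beyond the scatter). The second moves the fluoro within the same atoms, (4-fluorophenyl in place of 2-fluorophenyl on an amide-type nitrogen), and gives an at least 5.8-fold lower number from compound 2 to compound 3 (0.76 log units; beyond the scatter). Both steps are at least modest in size; since compound 2 sits at a limit, their true size is not known.

Compound 4 `FC(F)(F)c1ccc(NC(=S)N/N=C/c2ccc3ccccc3n2)cc1` is not yet measured in this assay. It differs from compound 3 by trifluoromethyl in place of fluoro on an aromatic carbon. This is the same kind of change as that from compound 2 to compound 1, but the place is not the same: there the trifluoromethyl enters ortho to a large group, here para to a large group. Among the measured compounds shown here, the one measured instance of this kind of change is only a lower bound on the step.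

The step from compound 3 to compound 4 is expected to be a 2.8-fold lower number from compound 3 to compound 4 (0.45 log units; beyond the scatter), resting on the bound from compound 2 to compound 1 of an at least 7.5-fold lower number from compound 2 to compound 1 (0.87 log units; beyond the scatter) and on the different place of the change. Compound 4 is estimated at 6000 nM, within 2000 nM to 20000 nM.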

Compound 4, half-maximal inhibitory concentration: 34900 nM
Beside the measured number, compound 4's estimate is 5.8-fold (0.76 log units) below it; measured number outside the range, above it.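

In this assay, trifluoromethyl in place of fluoro gives a 2.1-fold higher number from compound 3 to compound 4 (0.31 log units; beyond the scatter), so the change keeps neither its size nor its direction when carried from one core to the other in this series: the same change on two cores in this assay, an at least 7.5-fold lower number (0.87 log units; beyond the scatter) from compound 2 to compound 1 and a 2.1-fold higher number (0.31 log units; beyond the scatter) from compound 3 to compound 4, at least 15-fold (1.19 log units) apart, beyond the scatter of two such steps
Compound 2 is reported only at a limit of the assay, so the earlier step has no known size and stands only as a bound: the limit of > 100000 nM in this assay, at which 1 of the 4 values shown sits.
With a single pair for each place, the change here sitting para to a large group, the data do not show whether the place of the change or something else sets the gap, and they give no rule for any further core.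

The compounds shown leave open how the step would read with the unsubstituted phenyl as the reference, which would set both fluoro and trifluoromethyl against a common starting point. Also open, as far as these compounds go, is whether other groups at the same place, such as chloro, methoxy or an amine, would stay close to compound 3 or follow compound 4.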